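From a hydroxymethyl alkyne to a tert-butyl alkyne

The source may report more compounds than this note shows. Statements on the series, on what has been measured and on what is new or still open speak of the compounds shown alone.

Compound 2 `O=c1[nH]c(=O)n([C@H]2C[C@H](O)[C@@H](CO)O2)cc1C#CCO` has been tested in a functional assay on L1210 cells (Mus musculus); a higher number here means a weaker inhibitor, a lower number a stronger inhibitor. For compound 2 this assay reports only a limit, > 1000 ug/mL, and no number. Compound 1 `CCCC/C=C\c1cn([C@H]2C[C@H](O)[C@@H](CO)O2)c(=O)[nH]c1=O` carries hex-1-en-1-yl where compound 2 carries 3-hydroxyprop-1-yn-1-yl; in this assay compound 1 gives 361 ug/mL. Among the measured compounds shown here, the step of an at least 2.7-fold higher number from compound 1 to compound 2 (0.44 log units; beyond the scatter) is the only measured step, and it leaves compound 2 at the limit of > 1000 ug/mL in this assay, at which 1 of the 2 values shown sits. Compound 3 `CC(C)(C)C#Cc1cn([C@H]2C[C@H](O)[C@@H](CO)O2)c(=O)[nH]c1=O` differs from compound 2 by tert-butyl in place of hydroxymethyl on a triple-bonded carbon. Read one bond further out, the same change is 3-hydroxyprop-1-yn-1-yl to 3,3-dimethylbut-1-yn-1-yl. Because the step of an at least 2.7-fold higher number from compound 1 to compound 2 (0.44 log units; beyond the scatter) brought in hydroxymethyl and weakened inhibition, compound 3, which removes hydroxymethyl again, is expected to move back toward the number of compound 1, though from a limit the size of that move cannot be fixed. Compound 3 is therefore expected to give about 400 ug/mL in this assay, within 100 ug/mL to 1500 ug/mL, which would be a step of an at least 2.5-fold lower number from compound 2 to compound 3 (0.39 log units; beyond the scatter) measured against the limit.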

Compound 3, concentration for 50% inhibition: 287 ug/mL
Beside the measured number, compound 3's estimate is 1.4-fold (0.14 log units) above it; low and high end bracket the measured number.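

Among the compounds shown here, until this result, the triple bond and hydroxymethyl had entered together, so the weak result of compound 2 could not be assigned to either. Keeping the triple bond and exchanging hydroxymethyl for tert-butyl on the triple-bonded carbon in this assay gives an at least 3.4-fold lower number from compound 2 to compound 3 (0.54 log units; beyond the scatter), which shows that the triple bond alone does not bring the number of compound 2 to its limit. Replacing hex-1-en-1-yl with 3,3-dimethylbut-1-yn-1-yl on an aromatic carbon gives a 1.3-fold lower number from compound 1 to compound 3 (0.10 log units; within the scatter), so these two groups cannot be told apart in this assay, and the earlier step to compound 2, with its limit, is only a bound on size: the limit of > 1000 ug/mL in this assay, at which 1 of the 3 values shown sits.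

The compounds shown leave open whether the hydroxyl of hydroxymethyl matters or the whole group does, which a methoxymethyl or aminomethyl group on the triple-bonded carbon would test. For the compounds shown here, they also leave open whether a methyl group or a longer chain such as pentyl in that place would give a number apart from the one compound 3 gives, 287 ug/mL.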